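The source may report more compounds than this note shows. Statements on the series, on what has been measured and on what is new or still open speak of the compounds shown alone.

Working notes on a small set of compounds tested in an ADME assay on 184B5 cells (Homo sapiens) for cytotoxicity, read by sulforhodamine B assay, with a stated time of 48 h; a lower number here means a stronger inhibitor of growth, a higher number a weaker inhibitor of growth.

Of the compounds shown here, three have numbers so far. Compound 1 `CN(C)CN1C(=O)C(=O)c2c(Br)cccc21` gives 77900 nM in this assay. Compound 2 `Cc1ccc2nc(/N=C3\C(=O)N(CN4CCCCC4)c4cccc(Br)c43)sc2c1` gives 85200 nM, and compound 3 `Cc1ccc2nc(/N=C3\C(=O)N(CN(c4ccccc4)c4ccccc4)c4cccc(Cl)c43)sc2c1` gives 67800 nM. Compound 1 stands second highest of the three numbers; its nearest neighbour is compound 2 and its furthest is compound 3, and both of those gaps lie within the scatter of repeated measurements, so no order among the three can be read from these values. All three sit in the weak range of the assay.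

Compound 4 `CCN(CC)CN1C(=O)C(=O)c2c(Br)cccc21` has not been measured yet. It differs from compound 1 in one place: diethylamino in place of dimethylamino on a saturated chain carbon bound to an amide-type nitrogen in a ring. The core and everything else are unchanged.

Among the compounds with values here, no step between two measured compounds is available to calibrate this change. The three measured compounds, which differ from one another in several places at once, all fall within the scatter of each other, which gives no sign that substituents at this position move the number much. The expectation for the step from compound 1 to compound 4 is therefore none beyond the scatter, a 1.0-fold lower number from compound 1 to compound 4 (0.02 log units; within the scatter), with the direction uncertain.

Compound 4 is estimated at 75000 nM in this assay, with a range from 35000 nM to 160000 nM, the number for compound 1 of 77900 nM being the anchor.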

Compound 4, concentration for 50% growth inhibition: 172000 nM
The estimate for compound 4 lay 2.3-fold (0.36 log units) below the measured number; the whole stated range lies below it.
By their numbers in this assay, from the lowest: compounds 3, 1 and 2 (each within the scatter of the next); then compound 4.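

In this assay, diethylamino in place of dimethylamino on a saturated chain carbon bound to an amide-type nitrogen in a ring gives a 2.2-fold higher number from compound 1 to compound 4 (0.34 log units; beyond the scatter), a modest step towards weaker inhibition of growth. Within the data shown here, the earlier compounds differ from one another in several places at once and offered no step at all, so this is the first reading of a change confined to this one group, and it shows that the number can move beyond the scatter when only the amine on this chain carbon is altered, with the core held constant. No measurement in hand explains the step, which stands as an observation from a single pair.

A single step cannot show whether the number keeps rising as the groups on this amine grow longer, or whether the rise belongs to diethylamino alone. Dipropylamino and morpholine on the same chain carbon of the core of compound 1 would bear on that question, and whether the step carries over to other cores also remains open.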